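The source may hold more compounds than are shown below. What is called first, only, known or untested is meant among the compounds shown, and "the series" means these compounds.

In a functional assay on LNCaP cells (Homo sapiens) for antiproliferative activity (on this read-out lower numbers stand for stronger inhibition and higher numbers for weaker inhibition), the starting point offers no number: compound 3 (`CCC[C@@H]1C[C@@H](c2ccc(Cl)c(Cl)c2)[C@H](NC(=O)c2cc(-c3c(Cl)cnn3C)c(Cl)o2)CN1`), which carries a propyl chain on the shared core, has the entry "not determined" (no result reported). The move to compound 4 (`Cn1ncc(Cl)c1-c1cc(C(=O)N[C@@H]2CN[C@H](CC(=O)NCCO)C[C@H]2c2ccc(Cl)c(Cl)c2)oc1Cl`) can therefore be described only by its structure: (2-hydroxyethyl)carbamoyl in place of ethyl on a saturated chain carbon bound to a saturated ring carbon. In words, (2-hydroxyethyl)carbamoyl stands in place of ethyl on a saturated chain carbon bound to a saturated ring carbon.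

Any guidance has to come from two relatives that carry an amide in this same chain. In this assay compound 1 (`Cn1ncc(Cl)c1-c1cc(C(=O)N[C@@H]2CN[C@H](CC(N)=O)C[C@H]2c2ccc(Cl)c(Cl)c2)oc1Cl`), whose amide is unsubstituted, gives 160 nM, and compound 2 (`Cn1ncc(Cl)c1-c1cc(C(=O)N[C@@H]2CN[C@H](CC(=O)NCC(O)CO)C[C@H]2c2ccc(Cl)c(Cl)c2)oc1Cl`), with 2,3-dihydroxypropyl in place of the amide hydrogen, gives 660 nM. Within the data shown here, this is the only measured step that bears on the change: a 4.1-fold higher number from compound 1 to compound 2 (0.62 log units; beyond the scatter). It is modest but beyond the scatter, and it points toward weaker inhibition.

Among the measured compounds shown here, with no value for compound 3, no step from it can be sized. For the measured compounds named here, compound 4 also has a hydroxyl-bearing substituent on the amide nitrogen, so a rise from the value of compound 1 is expected, of similar or smaller size than the one seen for compound 2. This rests on a single pair, so the range stays wide. For compound 4 the estimated value is 350 nM, with an expected range from 130 nM to 900 nM.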

Compound 4, half-maximal inhibitory concentration: 40 nM
For compound 4 the middle estimate is 8.8-fold (0.94 log units) above the measured one; measured number outside the range, below it.
By their numbers in this assay, from the lowest: compound 4; then compound 1; then compound 2.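

In this assay, putting a substituent on the amide nitrogen does not have to weaken inhibition, since 2-hydroxyethyl gives a 4.0-fold lower number from compound 1 to compound 4 (0.60 log units; beyond the scatter) while 2,3-dihydroxypropyl, the only such substituent shown earlier, gives a 4.1-fold higher number from compound 1 to compound 2 (0.62 log units; beyond the scatter) in the opposite direction. The two substituents differ by a single hydroxymethyl, yet removing it gives a 17-fold lower number from compound 2 to compound 4 (1.22 log units; beyond the scatter) and is the largest step in the series, so the outcome at this amide nitrogen depends strongly on the exact substituent and cannot be inferred from the presence of a hydroxyl alone. Compound 3 has no number, so the change from its propyl chain to ((2-hydroxyethyl)carbamoyl)methyl cannot be read, and no measurement at hand explains the gap between the two hydroxyl-bearing substituents.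

Open, on these data alone, is whether the free hydroxyl of the 2-hydroxyethyl group matters at all, which a 2-methoxyethyl or a 2-aminoethyl group on the amide nitrogen would help to show. Also open, as far as these compounds go, is how far the chain can change, as a 3-hydroxypropyl group would test on the amide nitrogen and a carboxylic acid in place of the amide would test on the chain.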